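From Nitro to Methyl: An Expected Cytotoxicity for Compound 4

The source may report more compounds than this note shows. Statements on the series, on what has been measured and on what is new or still open speak of the compounds shown alone.

This account follows a small set of close analogues through an ADME assay on HEL cells (Homo sapiens) for cytotoxicity, with a stated time of 3 days; on this read-out lower numbers stand for higher toxicity in this test and higher numbers for lower toxicity in this test. Compound 1 `CCC1(Cc2ccccc2)OS(=O)(=O)CC1=O` gives 200000 nM in this assay. Compound 3 `CC1(Cc2ccccc2)OS(=O)(=O)C=C1OCc1ccccc1` gives 68000 nM in this assay. Compound 2 `CCC1(Cc2ccccc2)OS(=O)(=O)C=C1OCc1ccc([N+](=O)[O-])cc1` is reported in this assay only as a limit, < 200000 nM, and not as a number. Its standing on the scale is therefore fixed only by that boundary, which is the limit of < 200000 nM in this assay, at which 1 of the 3 values shown sits.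

Among the measured compounds shown here, no pair of the measured compounds differs in a single place, so no measured step in this assay can be read off. The unmeasured compound 4 `CCC1(Cc2ccccc2)OS(=O)(=O)C=C1OCc1ccc(C)cc1` differs from compound 2 in one place: methyl in place of nitro on an aromatic carbon. Nothing measured in this set fixes the direction of such a change, and the two companions, compound 1 and compound 3, sit within a modest span of one another in this assay.

The expectation is that compound 4 lands close to where compound 2 is bounded, with a step in this assay estimated as a step that the limit leaves unreadable from compound 2 to compound 4, which is taken to fall within the usual scatter. The value of compound 4 in this assay is thus estimated at 100000 nM, with a range from 30000 nM to 250000 nM.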

Compound 4, half-maximal cytotoxic concentration: 41500 nM
Compound 4: middle estimate off by 2.4-fold (0.38 log units), on the high side; the measured number falls inside the stated range.
By their numbers in this assay, from the lowest: compounds 4 and 3 (each within the scatter of the next); then compound 1.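

Among the compounds shown here, no step from compound 2 to compound 4 can be read in this assay, because compound 2 stands only as a limit and not as a number: the limit of < 200000 nM in this assay, at which 1 of the 4 values shown sits.

The compounds shown leave open in which direction, and how far, methyl in place of nitro on an aromatic carbon moves the read-out in this assay.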